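From compound 1 to compound 4: a cyclohexyl added

A few compounds are considered here, and "the series" means these few. Any claim that something is new, unique, unknown or untested is made for them only; others in the source may bear on it.

Measured in an ADME assay on BHK-21 cells (Mesocricetus auratus) for cytotoxicity, read by MTT assay; on this read-out higher numbers stand for lower toxicity in this test and lower numbers for higher toxicity in this test:
compound 1 (`CC(=O)c1ccc2[nH]c(-c3ccccc3)nc2c1`) gives > 100000 nM
compound 2 (`CC(=O)c1ccc2[nH]c(-c3ccc(C(F)(F)F)cc3)nc2c1`) gives > 100000 nM
compound 3 (`C/C(=N\NC(N)=O)c1ccc2[nH]c(-c3ccccc3)nc2c1`) gives > 100000 nM

Compound 1 stands at a limit of the assay, > 100000 nM, and not at a number. The same holds across the series, which shows (the limit of > 100000 nM in this assay, at which 3 of the 3 values shown sit). Compound 4 (`CC(=O)c1ccc2c(c1)nc(-c1ccccc1)n2C1CCCCC1`) differs from compound 1 by cyclohexyl in place of hydrogen on an aromatic nitrogen. For the measured compounds named here, two measured steps bear on it only loosely, since both lie elsewhere on the molecule: a step that the two limits leave unreadable from compound 1 to compound 2 and a step that the two limits leave unreadable from compound 1 to compound 3. Neither gives a size to carry over. The expected change in this assay is therefore a number no higher from compound 1 to compound 4 (the limit leaves the size open), with none beyond the scatter and a result at the same limit quite likely. Compound 4 is estimated at 100000 nM, with an expected range from 30000 nM to 300000 nM.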

Compound 4, half-maximal cytotoxic concentration: 100000 nM
Beside the measured number, compound 4's estimate shows no gap at the digits printed; low and high end bracket the measured number.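

In this assay, compound 4 is the only compound shown that gives a number and not a limit, 100000 nM, so the aromatic nitrogen is the one place where a change has yielded a readable value. Compound 1 gives > 100000 nM, which is a limit. Cyclohexyl in place of hydrogen thus gives a number no higher from compound 1 to compound 4 (the limit leaves the size open), and the size stays open because of where the series sits: the limit of > 100000 nM in this assay, at which 3 of the 4 values shown sit.

The compounds shown leave open whether a methyl group, a longer chain or a chain carrying an amine on this nitrogen would also give a number in this assay. They also leave open how cyclohexyl at this place behaves alongside the trifluoromethyl of compound 2.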